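A few compounds are considered here, and "the series" means these few. Any claim that something is new, unique, unknown or untested is made for them only; others in the source may bear on it.

For the measured compounds named here, the three compounds measured so far share one core and differ in a single group on one aromatic ring. Compound 1 `Cc1ccc(C2=NN(c3nc(-c4ccc(F)cc4)cs3)C(c3ccc(F)cc3)C2)s1` carries a fluoro there, and in a functional assay on A549 cells (Homo sapiens) for antiproliferative activity, read by XTT assay, with a stated time of 24 h (on this read-out lower numbers stand for stronger inhibition and higher numbers for weaker inhibition), compound 1 gives 125 ug/mL. Compound 2 `Cc1ccc(C2=NN(c3nc(-c4ccccc4)cs3)C(c3ccc(F)cc3)C2)s1` carries hydrogen in its place, and in this assay compound 2 reaches only a limit of the assay, > 500 ug/mL. Compound 3 `Cc1ccc(C2=NN(c3nc(-c4ccc(C(F)(F)F)cc4)cs3)C(c3ccc(F)cc3)C2)s1` carries trifluoromethyl, and in this assay compound 3 likewise gives only a limit, > 500 ug/mL. Compound 3 thus stands at the limit of > 500 ug/mL in this assay, at which 2 of the 3 values shown sit, without a number of its own. The steps of an at least 4.0-fold higher number from compound 1 to compound 2 (0.60 log units; beyond the scatter) and an at least 4.0-fold higher number from compound 1 to compound 3 (0.60 log units; beyond the scatter) both lie beyond the scatter, whereas the step that the two limits leave unreadable from compound 2 to compound 3 stays unreadable, with both of its ends at the limit.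

Compound 4 `COc1ccc(-c2csc(N3N=C(c4ccc(C)s4)CC3c3ccc(F)cc3)n2)cc1` differs from compound 3 by methoxy in place of trifluoromethyl on an aromatic carbon. Going by the values given here, no measured step involves a methoxy, so the two readable steps bear on it only indirectly: of the three groups tried, only the fluoro of compound 1 yielded a number, and the other two, in compound 2 and compound 3, did not. Compound 4 is therefore expected to remain near the limit, and the step of an at least 1.2-fold lower number from compound 3 to compound 4 (0.09 log units; that floor lies within the scatter) is expected to be small or absent. In this assay compound 4 is estimated at 400 ug/mL, within a range from 130 ug/mL to 800 ug/mL.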

Compound 4, half-maximal inhibitory concentration: 184 ug/mL
Beside the measured number, compound 4's estimate is 2.2-fold (0.34 log units) above it, within the range that was stated.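

For the compounds shown here, compound 4 shows that in this assay fluoro is not the only group at this position on the aromatic ring that gives a number, since methoxy gives one too, with an at least 2.7-fold lower number from compound 3 to compound 4 (0.43 log units; beyond the scatter) and an at least 2.7-fold lower number from compound 2 to compound 4 (0.43 log units; beyond the scatter). Set against fluoro, methoxy gives a 1.5-fold higher number from compound 1 to compound 4 (0.17 log units; within the scatter), so the two groups cannot be told apart here, and the change from 4-(trifluoromethyl)phenyl to 4-methoxyphenyl moves the compound from a limit to the level of compound 1. The position now divides into two groups with a number of their own and two without, and compound 2 and compound 3 remain the pair that gives only a limit: the limit of > 500 ug/mL in this assay, at which 2 of the 4 values shown sit.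

How far compound 2 and compound 3 lie past that limit stays unknown, so the step between them cannot be read, and no cause for the split among the four groups can be drawn from these values. The compounds shown also leave open whether a chloro, a hydroxyl or an amine at this position would give a number like those of compound 1 and compound 4, or only a limit.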